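Thiophene for phenyl on the guanidine side chain

This account rests on a few compounds, and the source may have more. Where it says the series, first, only, none or still open, it means among the compounds named here.

Measured in a functional assay on cardiac atrium for agonist activity at histamine H2 receptor (Cavia porcellus); on this read-out lower numbers stand for lower potency and higher numbers for higher potency (the scale is a negative logarithm):
Compound 1 `N=C(NCCCc1c[nH]cn1)NCCSC(c1ccccc1)c1ccccn1` gives 6.6
Compound 2 `N=C(NCCCc1c[nH]cn1)NCCC(c1ccccc1)c1ccccn1` gives 7.39
Compound 3 `N=C(NCCCc1c[nH]cn1)NCCC(c1ccc(Cl)c(Cl)c1)c1ccccn1` gives 8.19

Compound 2 stands second highest of these three numbers, beyond the scatter above compound 1 and beyond the scatter below compound 3. The step from compound 2 to compound 4 `N=C(NCCCc1c[nH]cn1)NCCC(c1ccccn1)c1cccs1` is thiophen-2-yl in place of phenyl on a saturated chain carbon bound to an aromatic carbon and a saturated chain carbon. Going by the values given here, no measured step exchanges the phenyl for another ring; the only step at this place, a number 0.80 log units higher from compound 2 to compound 3 (beyond the scatter), adds chlorines to the phenyl and is modest. With nothing directly comparable, the expected step of a number 0.11 log units higher from compound 2 to compound 4 (within the scatter) is none beyond the scatter. Compound 4 is therefore estimated in this assay at 7.5, within 6.9 to 8.1.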

Compound 4, negative logarithm of the half-maximal effective concentration: 7.16
Beside the measured number, compound 4's estimate is 0.34 log units above it; measured number inside the range.
By their numbers in this assay, from the lowest: compound 1; then compounds 4 and 2 (each within the scatter of the next); then compound 3.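

In this assay the five-membered thiophen-2-yl takes the place of the phenyl on the saturated chain carbon with a number 0.23 log units lower from compound 2 to compound 4 (within the scatter), so a ring with sulfur is tolerated here and the two rings cannot be told apart. The same exchange made on the chlorinated ring gives a number 1.03 log units lower from compound 3 to compound 4 (beyond the scatter), which leaves the 3,4-dichlorophenyl alone in standing apart among these rings. Nothing available accounts for either result. Still open, from the compounds shown here alone, is whether chlorine on the thiophen-2-yl would give a step like the one seen on the phenyl. Also open, going by these compounds, is how a furan-2-yl or a cyclohexyl ring would read at this place.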